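Swapping the ester tail of compound 1

A few compounds are considered here, and "the series" means these few. Any claim that something is new, unique, unknown or untested is made for them only; others in the source may bear on it.

Compound 1 `C/C=C1/[C@H](O[C@@H]2O[C@H](CO)[C@@H](O)[C@H](O)[C@H]2O)OC=C(C(=O)OC)[C@H]1CC(=O)OCCC1CCCCC1`: 2000 nM
Compound 2 `C/C=C1/[C@H](O[C@@H]2O[C@H](COC(C)=O)[C@@H](OC(C)=O)[C@H](OC(C)=O)[C@H]2OC(C)=O)OC=C(C(=O)O)[C@H]1CC(=O)O`: > 20000 nM
Compound 3 `C/C=C1/[C@H](O[C@@H]2O[C@H](CO)[C@@H](O)[C@H](O)[C@H]2O)OC=C(C(=O)OC)[C@H]1CC(=O)OCCCCCCCCCCCCCCC`: 1600 nM

All three were tested in a functional assay on SK-BR-3 cells (Homo sapiens) for antiproliferative activity, read by MTT assay, with a stated time of 72 h; a lower number here means a stronger inhibitor, a higher number a weaker inhibitor. Compound 1 gives 2000 nM there, and compound 3 gives 1600 nM; the gap between them lies within the usual scatter, so the two read as equal. Compound 2 gives > 20000 nM, which is a limit of the assay rather than a number (the limit of > 20000 nM in this assay, at which 1 of the 3 values shown sits). Compound 4 `C/C=C1/[C@H](O[C@@H]2O[C@H](CO)[C@@H](O)[C@H](O)[C@H]2O)OC=C(C(=O)OC)[C@H]1CC(=O)OCc1ccco1` is not yet measured. It differs from compound 1 in one place: furan-2-yl in place of cyclohexylmethyl on a saturated chain carbon bound to an oxygen next to a carbonyl group. For the measured compounds named here, no measured pair shows a change of this kind, so the size of the step is uncertain; a modest loss is expected, a 1.5-fold higher number from compound 1 to compound 4 (0.18 log units; within the scatter). Compound 4 is therefore estimated to give 3000 nM, somewhere between 1000 nM and 12000 nM.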

Compound 4, half-maximal inhibitory concentration: > 15000 nM
Compound 4: no number, only a limit; the forecaster's own chance of this, stated with the estimate: 15%; middle value at least 5.0-fold (0.69 log units) away from the limit.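

Compound 1 and compound 3 read as equal in this assay, which made the ester tail look open to change. This result shows that it is not open to every group: furan-2-yl in place of cyclohexylmethyl gives an at least 7.5-fold higher number from compound 1 to compound 4 (0.87 log units; beyond the scatter). The full size of the loss stays unknown, since compound 4 reaches only a limit of the assay: the limit of > 15000 nM in this assay, at which 1 of the 4 values shown sits.

As far as these compounds go, it remains open whether the ring's oxygen or the shorter tail matters more. A phenyl in the same place, which keeps an aromatic ring without the oxygen, would help separate the two.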